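Swapping a Methoxy Group for Hydrogen

This account rests on a few compounds, and the source may have more. Where it says the series, first, only, none or still open, it means among the compounds named here.

For the measured compounds named here, in a functional assay on HOP-92 cells (Homo sapiens) for inhibition, read by sulforhodamine B assay, with a stated time of 48 h, tested at 10 uM (a lower number here means less inhibition of growth, a higher number more inhibition of growth at the concentration tested), compound 1 `COc1ccc(-c2nc3sc(-c4ccccc4)cn3n2)cc1` gives 32%, the higher of the two numbers available so far. In this assay compound 2 `COc1cc(-c2nc(N)n(CC(=O)Nc3ccc(/C(C)=N\O)cc3)n2)cc(OC)c1OC` gives 11.8%, and the gap between these two values lies beyond the usual scatter of repeated measurements. These two compounds do not differ in just one place, so neither value shows what a single small change does on its own.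

The next compound to be tested is compound 3 `c1ccc(-c2nc3sc(-c4ccccc4)cn3n2)cc1`. It keeps the core of compound 1 but has hydrogen in place of methoxy on an aromatic carbon, para to a large group (hydrogen in place of methoxy on an aromatic carbon). Going by the values given here, nothing measured so far isolates this change, so any forecast must remain cautious and the range must stay wide. The expected result is a slight fall at most, with no shift beyond the scatter, and the estimated change is a number 4 percentage points lower from compound 1 to compound 3 (within the scatter). The inhibition expected for compound 3 is 28%, within an estimated range of 12% to 46%.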

Compound 3, percent growth inhibition at one concentration: 25%
Compound 3: the middle estimate sits 3 percentage points above what was measured; low and high end bracket the measured number.
By their numbers in this assay, from the lowest: compound 2; then compounds 3 and 1 (each within the scatter of the next).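

In this assay, for the compounds shown here, this is the first comparison that isolates a single change: putting hydrogen in place of methoxy on an aromatic carbon, para to a large group, gives a number 7 percentage points lower from compound 1 to compound 3 (within the scatter). The methoxy group can therefore be removed from this position without a change that can be told apart from ordinary assay variation, as the remaining inhibition of compound 3, at 25%, still matches that of compound 1 within the scatter. This one pair shows only that the result holds for hydrogen and methoxy on this core, and no supporting data are available to explain why the swap leaves so little mark on the read-out.

Still open, going by these compounds, is how other groups at this same position would behave, for example an amine, a carboxylic acid or a longer chain, since two substituents cannot define a trend. It is also unknown whether replacing methoxy with hydrogen would give a similarly small step on a different core, or in a different cell line.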